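The compounds below may be only part of what the source reports. "The series", "measured", "known", "first", "only" and "open" are said of these compounds alone.

Three related compounds have been measured in a physicochemical assay for solubility, at pH 7.4; on this read-out higher numbers stand for higher solubility and lower numbers for lower solubility. Compound 1 `C[C@H]1[C@H](N)CN1c1c(F)c(N)c2c(=O)c(C(=O)O)cn(C3CC3)c2c1F` gives 37.7 ug/mL, compound 2 `CN[C@H]1CN(c2c(F)cc3c(=O)c(C(=O)O)cn(C4CC4)c3c2F)[C@@H]1C` gives 13.1 ug/mL, and compound 3 `CN(C)C1CN(c2c(F)cc3c(=O)c(C(=O)O)cn(C4CC4)c3c2F)C1` gives 58 ug/mL. Compound 3 and compound 1 lie within the scatter of each other, so neither can be ranked above the other, while compound 2 sits clearly lower than compound 3.

Going by the values given here, the next compound, compound 4 `C[C@H]1[C@H](N)CN1c1c(F)cc2c(=O)c(C(=O)O)cn(C3CC3)c2c1F`, has no measurement yet. Its structural change from compound 3 is a group of 6 heavy atoms (4 carbon, 2 nitrogen; one four-membered non-aromatic ring with 1 hetero atom) in place of a group of 7 heavy atoms (5 carbon, 2 nitrogen; one four-membered non-aromatic ring with 1 hetero atom), on an aromatic carbon. The 3-(dimethylamino)azetidin-1-yl group leaves, and the group that enters has no common name and carries 2 defined stereocentres.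

Among the compounds with values here, only one measured step involves a swap at this aromatic carbon: a 4.4-fold higher number from compound 2 to compound 3 (0.65 log units; beyond the scatter). That modest step, beyond the scatter, is the one that brought in the 3-(dimethylamino)azetidin-1-yl group, which now leaves. One step is thin evidence, and the group entering here is a different one, so the comparison is only a rough guide. Even so, a move to a lower number of similar or somewhat smaller size is expected in this assay. The estimated step is a 2.6-fold lower number from compound 3 to compound 4 (0.42 log units; beyond the scatter). For compound 4 the expected value is 22 ug/mL, with an estimated range of 8 ug/mL to 60 ug/mL.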

Compound 4, solubility: 23.2 ug/mL
The estimate for compound 4 lay 1.1-fold (0.02 log units) below the measured number; the measured number falls inside the stated range.
By their numbers in this assay, from the lowest: compounds 2, 4, 1 and 3 (each within the scatter of the next, the first and the last beyond it).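

In this assay, the group with 2 defined stereocentres replaces the 3-(dimethylamino)azetidin-1-yl group on the aromatic carbon with a 2.5-fold lower number from compound 3 to compound 4 (0.40 log units; beyond the scatter) as the result, while the comparison with the other group tried at this carbon gives a 1.8-fold higher number from compound 2 to compound 4 (0.25 log units; within the scatter) and so leaves those two groups unranked. Compound 3 therefore stands clearly apart from both of the other groups seen at this carbon, although that holds for these three compounds alone. Going by these compounds alone, the same series also gives a first look at a second place on the core, where hydrogen replaces amino on an aromatic carbon with a 1.6-fold lower number from compound 1 to compound 4 (0.21 log units; within the scatter) as the result, so that single pair shows no readable effect of the amino group in this assay. Nothing available here explains any of these differences.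

As far as these compounds go, how a six-membered ring such as piperazin-1-yl, or a plain dimethylamino group, would compare on the same aromatic carbon remains open. From the compounds shown here alone, it is also open whether a fluoro or methyl group in place of that amino group would stay as close to compound 4 as compound 1 does.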